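Methoxy for chloro with compound 3 at the limit

The source may hold more compounds than are shown below. What is called first, only, known or untested is meant among the compounds shown, and "the series" means these compounds.

Compound 3 `Clc1ccc(C2=NN(c3ccc(-c4ccccc4)nn3)C(c3ccc(Cl)cc3)C2)cc1` is the starting point. In a functional assay on Caco-2 cells (Homo sapiens) for antiproliferative activity, read by MTT assay, with a stated time of 24 h (a higher number here means a weaker inhibitor, a lower number a stronger inhibitor), compound 3 gives > 100000 nM, which is a limit of the assay and not a number. Compound 1 `Clc1ccc(C2CC(c3ccccc3)=NN2c2ccc(-c3ccccc3)nn2)cc1` gives 100000 nM in this assay. Compound 2 `COc1ccc(C2CC(c3ccccc3)=NN2c2ccc(-c3ccccc3)nn2)cc1` gives > 100000 nM in this assay, again a limit rather than a number. Compound 3 therefore shares (the limit of > 100000 nM in this assay, at which 2 of the 3 values shown sit), and nothing in the series reaches a measurable inhibition.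

Compound 4 `COc1ccc(C2CC(c3ccc(Cl)cc3)=NN2c2ccc(-c3ccccc3)nn2)cc1` differs from compound 3 by methoxy in place of chloro on an aromatic carbon. The same exchange has been measured once, from compound 1 to compound 2: a number no lower from compound 1 to compound 2 (the limit leaves the size open). The other measured step, a number no lower from compound 1 to compound 3 (the limit leaves the size open), concerns the chloro that compound 3 carries on its second aryl ring and likewise leads no lower. Both steps point to the limit, so for compound 4 the expected step is a number no higher from compound 3 to compound 4 (the limit leaves the size open), no movement beyond the scatter, with a further limit the most probable outcome. The estimate for compound 4 in this assay is 100000 nM, expected between 50000 nM and 200000 nM.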

Compound 4, half-maximal inhibitory concentration: > 100000 nM
Compound 4 was reported as a limit; the forecaster's own chance of this, stated with the estimate: 85%; the middle value sits exactly at the limit.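

In this assay compound 4 gives > 100000 nM, a limit of the assay and not a number. For the compounds shown here, compound 2 and compound 3 are also limits, so no new step to compound 4 can be read. Most of the series now sits there: the limit of > 100000 nM in this assay, at which 3 of the 4 values shown sit. Going by these compounds, how far the true values of compound 2, compound 3 and compound 4 lie past that limit remains open.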